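The source may hold more compounds than are shown below. What is called first, only, known or untested is meant among the compounds shown, and "the series" means these compounds.

The measured compounds:
compound 1, `Cc1ccc(N2CCN(C(=S)SCc3ccc(C(=O)Nc4ccccc4N)cc3)CC2)cc1`, 19.8%
compound 2, `CN1CCN(C(=S)SCc2ccc(C(=O)Nc3ccccc3N)cc2)CC1`, 84.4%
compound 3, `Nc1ccccc1NC(=O)c1ccc(CSC(=S)N2CCN(Cc3cccnc3)CC2)cc1`, 64.6%

These three share one core and differ only in the group on an amine nitrogen in a ring. In a functional assay on MGC-803 cells (Homo sapiens) for antiproliferative activity, read by CCK-8 assay, with a stated time of 72 h, tested at 8 uM (on this read-out lower numbers stand for a weaker effect and higher numbers for a stronger effect at the one concentration tested), compound 3 gives 64.6%, the second highest of the three numbers: compound 2 stands closest, with a step of a number 19.8 percentage points lower from compound 2 to compound 3 (beyond the scatter), while compound 1 lies furthest away, with a step of a number 44.8 percentage points higher from compound 1 to compound 3 (beyond the scatter).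

Compound 4, `Nc1ccccc1NC(=O)c1ccc(CSC(=S)N2CCN(c3ccccc3F)CC2)cc1`, is the next step from compound 3. Its change is 2-fluorophenyl in place of (pyridin-3-yl)methyl on an amine nitrogen in a ring. Among the measured compounds shown here, two measured steps bear on it. The step of a number 44.8 percentage points higher from compound 1 to compound 3 (beyond the scatter) went from an aryl group placed directly on the ring nitrogen to an arylmethyl group, and the step of a number 64.6 percentage points higher from compound 1 to compound 2 (beyond the scatter) went from the same aryl group to a methyl. Compound 4 moves the other way, back to an aryl group placed directly on the ring nitrogen, though compound 1 carries 4-methylphenyl and compound 4 carries 2-fluorophenyl, so no exact match exists among the measured compounds. On this basis a large fall is expected, a number 34.6 percentage points lower from compound 3 to compound 4 (beyond the scatter). Compound 4 is therefore estimated at 30%, with a range from 10% to 58%.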

Compound 4, a percentage reported as inhibition, at one concentration (the size of the read-out at that concentration, not a potency): 86.4%
The estimate for compound 4 lay 56.4 percentage points below the measured number, and the stated range ends below it.
By their numbers in this assay, from the lowest: compound 1; then compound 3; then compounds 2 and 4 (each within the scatter of the next).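

In this assay an aromatic ring placed directly on the ring nitrogen does not by itself go with a low number: exchanging 4-methylphenyl for 2-fluorophenyl gives a step of a number 66.6 percentage points higher from compound 1 to compound 4 (beyond the scatter) even though the link to the nitrogen stays the same. The same group stands level with the much smaller methyl, with a step of a number 2 percentage points higher from compound 2 to compound 4 (within the scatter) and it also exceeds (pyridin-3-yl)methyl, with a step of a number 21.8 percentage points higher from compound 3 to compound 4 (beyond the scatter) so across these four compounds the numbers are not sorted by whether an aromatic ring sits directly on the nitrogen or one carbon away from it, and compound 1 is the one that stands apart from the other three. Nothing available here accounts for the gap between the two groups with a directly attached aromatic ring.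

The two groups differ both in the atom they carry on the phenyl ring and in where it sits, so the compounds shown leave open which of these two differences matters. An unsubstituted phenyl, 4-fluorophenyl or 2-methylphenyl on the same nitrogen would separate them, and a benzyl group would show whether the pyridine nitrogen of compound 3 counts.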